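The source may report more compounds than this note shows. Statements on the series, on what has been measured and on what is new or still open speak of the compounds shown alone.

Compound 1 `CC(C)(N)CN(C(=O)[C@@H]1C[C@H]1c1ccccc1)c1ccc(-c2ccccc2)cc1` is the starting point of this series. In a functional assay for agonist activity at G protein-coupled receptor 88 (Homo sapiens), read by HTRF and cAMP accumulation (on this read-out higher numbers stand for an effect only at larger amounts of compound and lower numbers for an effect already at smaller amounts), compound 1 gives 1.4 nM. Compound 2 `CC(C)C[C@H](N)CCN(C(=O)[C@@H]1C[C@H]1c1ccccc1)c1ccc(-c2ccccc2)cc1` differs from it only in the amine-bearing chain: 2-amino-4-methylpentyl in place of 1-amino-1-methylethyl on a saturated chain carbon bound to an amide-type nitrogen. In this assay compound 2 gives 3 nM, which is a 2.1-fold higher number from compound 1 to compound 2 (0.33 log units; beyond the scatter). Going by the values given here, compound 3 `CC[C@H](C)[C@H](N)CN(C(=O)[C@@H]1C[C@H]1c1cccc(F)c1)c1ccc(-c2ccccc2)cc1` differs from both in more than one place, so no single step leads to it. In this assay compound 3 gives 560 nM, the highest of the three numbers, separated from compound 2 and from compound 1 by gaps well beyond the scatter.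

Compound 4 `CC[C@H](C)[C@H](N)CN(C(=O)[C@@H]1C[C@H]1c1ccsc1)c1ccc(-c2ccccc2)cc1` has not yet been measured. It differs from compound 3 in one place: thiophen-3-yl in place of 3-fluorophenyl on a saturated ring carbon. Among the compounds with values here, no measured step touches the aromatic group on the three-membered ring; the one measured step concerns the amine-bearing chain only, so it gives no direct guide here. With nothing to point either way, the expected step is a 1.1-fold lower number from compound 3 to compound 4 (0.05 log units; within the scatter), not beyond the scatter. Compound 4 is therefore expected to give about 500 nM in this assay, within a range from 150 nM to 1800 nM.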

Compound 4, half-maximal effective concentration: 450 nM
Compound 4: the middle estimate sits 1.1-fold (0.05 log units) above what was measured; low and high end bracket the measured number.
By their numbers in this assay, from the lowest: compound 1; then compound 2; then compounds 4 and 3 (each within the scatter of the next).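

In this assay, this first measured change to the aromatic group on the three-membered ring gives a 1.2-fold lower number from compound 3 to compound 4 (0.09 log units; within the scatter), so the step cannot be told apart from the ordinary spread of repeated measurements. At this saturated ring carbon, a five-membered aromatic ring with 1 hetero atom and 5 heavy atoms can therefore replace a six-membered carbon-only aromatic ring with 7 heavy atoms, with no measurable difference in this pair. No supporting evidence is available to explain why these two groups read alike.

On these data alone, it remains open whether other aromatic groups at this place, such as furan-3-yl or pyridin-3-yl, would also read alike. It is also unknown whether the same exchange would give a similar result with the 1-amino-1-methylethyl chain of compound 1.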